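A Methylamino Swap at a Cytotoxicity Limit

The source may hold more compounds than are shown below. What is called first, only, known or untested is meant among the compounds shown, and "the series" means these compounds.

Compound 1, `O=C(Nc1ccc(-n2ncc3c(Br)cccc32)cc1)Nc1ccc(Cl)c(C(F)(F)F)c1`, gives 16600 nM in a functional assay on SGC-7901 cells (Homo sapiens) for cytotoxicity, read by MTT assay, with a stated time of 72 h; a lower number here means a stronger inhibitor, a higher number a weaker inhibitor.
Compound 2, `O=C(Nc1ccc(-n2ncc3ccccc32)cc1)Nc1ccc(Cl)c(C(F)(F)F)c1`, gives only a limit of > 32000 nM in this assay.

Compound 2 therefore stands at the limit of > 32000 nM in this assay, at which 1 of the 2 values shown sits, and has no number of its own. Among the compounds with values here, the one measured step, an at least 1.9-fold higher number from compound 1 to compound 2 (0.28 log units; that floor lies within the scatter), reaches only that limit. Compound 3 is `CNc1cccc2c1cnn2-c1ccc(NC(=O)Nc2ccc(Cl)c(C(F)(F)F)c2)cc1`, made from compound 2 by methylamino in place of hydrogen on an aromatic carbon. Within the data shown here, no measured step touches the same position, and the single step from compound 1 offers no guide beyond its floor. Compound 3 is therefore expected to stay weak, with an at least 1.2-fold lower number from compound 2 to compound 3 (0.10 log units; that floor lies within the scatter) in this assay, an estimated 25000 nM, between 8000 nM and 80000 nM.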

Compound 3, half-maximal inhibitory concentration: 6900 nM
Beside the measured number, compound 3's estimate is 3.6-fold (0.56 log units) above it, and the stated range ends above it.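

At this position, methylamino gives the lowest number of the three compounds in this assay, with an at least 4.6-fold lower number from compound 2 to compound 3 (0.66 log units; beyond the scatter) and, against bromo, a 2.4-fold lower number from compound 1 to compound 3 (0.38 log units; beyond the scatter). Hydrogen and bromo had not been separated beyond the scatter, so this is the first sign that a change here can move the number. The first of these steps is only a floor, as compound 2 has only a limit: the limit of > 32000 nM in this assay, at which 1 of the 3 values shown sits.

The compounds shown leave open whether a plain amine, a dimethylamino group or a methoxy group here would lower the number further.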